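Chain-extended amide variant of compound 1: expected binding

The compounds below may be only part of what the source reports. "The series", "measured", "known", "first", "only" and "open" are said of these compounds alone.

Two compounds of the series have numbers in an assay on THP-1 cells for displacement of a labelled ligand from C-C chemokine receptor type 1 (Homo sapiens); a higher number here means a weaker inhibitor, a lower number a stronger inhibitor. Compound 1, `Cc1ccc(C(=O)N[C@@H](C(=O)N2CCC(c3ccc(Cl)cc3)CC2)C(C)C)cc1`, gives 25 nM there and has the lowest number of the two. Compound 2, `CC(C)C(NC(=O)c1ccccc1)C(=O)N1CCC(c2ccc(F)cc2)CC1`, gives 423 nM in this assay, a higher number than compound 1 by a margin that lies beyond the usual scatter. For the measured compounds named here, no pair of measured compounds differs in one place only, so no single counted step is available as a guide.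

Compound 3, `Cc1ccccc1CCC(=O)N[C@@H](C(=O)N1CCC(c2ccc(Cl)cc2)CC1)C(C)C`, is the untested member. It differs from compound 1 in one place: 2-(2-methylphenyl)ethyl in place of 4-methylphenyl on a carbonyl carbon. The group leaving and the group entering both carry one six-membered aromatic ring of carbon only; the entering group is larger and is attached through a chain.

Without a measured step of this kind in the series, the expected step from compound 1 to compound 3 is a 3.2-fold higher number from compound 1 to compound 3 (0.51 log units; beyond the scatter), a moderate move toward a higher number, with wide uncertainty in both directions. Compound 3 is therefore estimated at 80 nM in this assay, within a range from 15 nM to 450 nM.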

Compound 3, half-maximal inhibitory concentration: 19 nM
Estimate against measurement, compound 3: 4.2-fold (0.62 log units) above; the measured number falls inside the stated range.
By their numbers in this assay, from the lowest: compounds 3 and 1 (each within the scatter of the next); then compound 2.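

Compound 3 shows that the position on the carbonyl carbon holds more than the directly attached ring of compound 1: in this assay the exchange of 4-methylphenyl for 2-(2-methylphenyl)ethyl gives a 1.3-fold lower number from compound 1 to compound 3 (0.12 log units; within the scatter) and so leaves the two compounds indistinguishable. A larger group, with its one aromatic ring attached through a chain, is therefore tolerated here without any loss of binding that can be read from these numbers. The step carries two differences at once, the chain and the place of the methyl on the ring as the group names show, and no information at hand accounts for the result.

From the compounds shown here alone, what remains open is how far this tolerance extends, for instance with a longer chain ending in the same ring, or with 2-phenylethyl, which would separate the chain from the methyl. Also open, going by these compounds, is whether the aromatic ring is needed at all at this position, a question that a chain ending in an amine or a carboxylic acid in place of the ring would address.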